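Three Measured Benzimidazoles and a Fourth Awaiting Its Number

The compounds below may be only part of what the source reports. "The series", "measured", "known", "first", "only" and "open" are said of these compounds alone.

Measured so far:
compound 1, `COc1ccc(-c2ccc(-c3ccc(-c4nc5cc(C)ccc5[nH]4)cc3)cc2)cc1OC`, 1310 nM
compound 2, `Oc1cccc2[nH]c(-c3ccc(-c4ccc(-c5ccccc5)cc4)cc3)nc12`, 1110 nM
compound 3, `COc1ccc(-c2ccc(-c3ccc(-c4nc5c(O)cccc5[nH]4)cc3)cc2)cc1OC`, 1110 nM

All three were tested in a functional assay on Gurav cells (Homo sapiens) for inhibition, read by sulforhodamine B assay; on this read-out higher numbers stand for weaker inhibition of growth and lower numbers for stronger inhibition of growth. The three numbers lie close together: no change at the digits printed from compound 3 to compound 2 (within the scatter), and a 1.2-fold lower number from compound 1 to compound 3 (0.07 log units; within the scatter). None of the three can be called stronger or weaker than another on this evidence.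

Compound 2 and compound 3 share one core and differ in a single place: phenyl in place of 3,4-dimethoxyphenyl on an aromatic carbon. That swap left the number where it was. Compound 1 carries a different core from compound 3; the cores differ as follows: 5-methyl-1H-benzimidazol-2-yl in place of 4-hydroxy-1H-benzimidazol-2-yl on an aromatic carbon. This second change also stayed within the scatter.

The unmeasured compound 4, `Cc1ccc2[nH]c(-c3ccc(-c4ccc(-c5ccccc5)cc4)cc3)nc2c1`, relates to compound 1 as compound 2 relates to compound 3: phenyl in place of 3,4-dimethoxyphenyl on an aromatic carbon. The place of the change is described in the same words for both pairs, so it is the same change, seen in two pairs. Among the compounds with values here, its one measured step, no change at the digits printed from compound 3 to compound 2 (within the scatter), gives the only guide.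

For compound 4 in this assay the step from compound 1 is therefore expected to be small, about a 1.0-fold lower number from compound 1 to compound 4 (0.00 log units; within the scatter), because the same change produced no change at the digits printed from compound 3 to compound 2 (within the scatter). Compound 4 is accordingly estimated at 1300 nM, with a likely range from 700 nM to 2400 nM.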

Compound 4, concentration for 50% growth inhibition: 3310 nM
Compound 4: the middle estimate sits 2.5-fold (0.41 log units) below what was measured; the whole stated range lies below it.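

In this assay, putting phenyl in place of 3,4-dimethoxyphenyl on the core that carries 5-methyl-1H-benzimidazol-2-yl gives a 2.5-fold higher number from compound 1 to compound 4 (0.40 log units; beyond the scatter), a modest weakening of growth inhibition, whereas on the core that carries 4-hydroxy-1H-benzimidazol-2-yl the same change gave no change at the digits printed from compound 3 to compound 2 (within the scatter). Read alone, the two steps look different, but set side by side they cannot be told apart: the same change on two cores in this assay, no change at the digits printed (within the scatter) from compound 3 to compound 2 and a 2.5-fold higher number (0.40 log units; beyond the scatter) from compound 1 to compound 4, 2.5-fold (0.40 log units) apart, within the scatter of two such steps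

This does not show that the core alters what the change does, and it does not prove that the change carries over unaltered either, since two pairs with this much scatter cannot settle the matter in either direction.

The compounds shown leave open whether a ring with only one methoxy group would behave like the 3,4-dimethoxyphenyl compounds or like the phenyl ones, and how an amine or a carboxylic acid would behave on that ring. They also leave open what the same change from 3,4-dimethoxyphenyl to phenyl would do on a third core, which is what a firmer view of its transfer across the series would need.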